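Swapping fluoro for methoxy on the fused ring

The compounds below may be only part of what the source reports. "The series", "measured", "known", "first", "only" and "open" are said of these compounds alone.

Compound 1 `COc1ccc(-c2cc(C(=O)Nc3nc4ccc(F)cc4s3)nc3cc(-c4ccccc4)nn23)cc1` is the weaker of the two measured compounds: in a functional assay on HeLa cells (Homo sapiens) for cytotoxicity, read by MTT assay, with a stated time of 48 h (on this read-out higher numbers stand for weaker inhibition and lower numbers for stronger inhibition), compound 1 gives 41700 nM, while compound 2 `COc1ccc(-c2cc(C(=O)Nc3nc4ccc(F)cc4s3)nc3cc(-c4ccccc4)nn23)cc1OC` gives 8310 nM, a change of a 5.0-fold lower number from compound 1 to compound 2 (0.70 log units; beyond the scatter). Compound 3 `COc1ccc(-c2cc(C(=O)Nc3nc4ccc(OC)cc4s3)nc3cc(-c4ccccc4)nn23)cc1` differs from compound 1 by methoxy in place of fluoro on an aromatic carbon. Among the measured compounds shown here, the only measured step places a methoxy on a different ring, so it bears on this change only loosely; it shows that adding a methoxy can help, but nothing here shows it at this place. Compound 3 is therefore expected near compound 1, an estimated step of a 1.4-fold lower number from compound 1 to compound 3 (0.14 log units; within the scatter), giving about 30000 nM within 8000 nM to 100000 nM.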

Compound 3, half-maximal inhibitory concentration: 24500 nM
Estimate against measurement, compound 3: 1.2-fold (0.09 log units) above; low and high end bracket the measured number.
By their numbers in this assay, from the lowest: compound 2; then compounds 3 and 1 (each within the scatter of the next).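

In this assay, methoxy in place of fluoro on this fused ring gives a 1.7-fold lower number from compound 1 to compound 3 (0.23 log units; within the scatter), so the two groups cannot be told apart at this place. This place therefore takes the two heavy atoms of methoxy in place of the single fluorine with no clear loss or gain, whereas the earlier methoxy step, on a different ring, lay beyond the scatter. Nothing measured here explains this result.

Still open, from the compounds shown here alone, is whether an amine, a carboxylic acid or a longer chain such as butoxy at this place would give a clearer step. Also open, going by these compounds, is whether a second methoxy, as in compound 2, would combine with this one.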